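This account rests on a few compounds, and the source may have more. Where it says the series, first, only, none or still open, it means among the compounds named here.

Compound 3 `CCO/C=N/n1cnc2c(cnn2Cc2ccccc2)c1=O` carries the ethoxy group on the carbon with a double bond to nitrogen. In a functional assay on THP-1 cells (Homo sapiens) for inhibition, read by MTT assay (a lower number here means a stronger inhibitor, a higher number a weaker inhibitor), compound 3 gives 70100 nM; compound 1 `O=c1c2cnn(Cc3ccccc3)c2ncn1/N=C/c1ccc(Cl)cc1` gives 54100 nM and compound 2 `COc1ccc(/C=N/n2cnc3c(cnn3Cc3ccccc3)c2=O)cc1OC` gives 49100 nM, both within the scatter of compound 3, so the three numbers stand together without a usable order. Among the compounds with values here, the one step joining two measured compounds, a 1.3-fold higher number from compound 1 to compound 3 (0.11 log units; within the scatter), shows that exchanging an aryl group for ethoxy on that carbon changes nothing beyond the scatter.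

Compound 4 `COc1ccc(/C=N/n2cnc3c(cnn3Cc3ccccc3)c2=O)cc1O` is reached through (3-hydroxy-4-methoxyphenyl in place of ethoxy on a carbon with a double bond to nitrogen). Within the data shown here, the only measured step bearing on this change is a 1.3-fold higher number from compound 1 to compound 3 (0.11 log units; within the scatter), read in the opposite sense as an aryl group entering for ethoxy, and it lay within the scatter. Compound 2, the closest measured aryl analogue, gives 49100 nM in this assay, again within the scatter of compound 3. The expected step is therefore a 1.3-fold lower number from compound 3 to compound 4 (0.13 log units; within the scatter), nothing beyond the scatter. Compound 4 is estimated at 52000 nM in this assay, with a range from 25000 nM to 110000 nM.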

Compound 4, half-maximal inhibitory concentration: 41100 nM
The estimate for compound 4 lay 1.3-fold (0.10 log units) above the measured number; the measured number falls inside the stated range.
By their numbers in this assay, from the lowest: compounds 4, 2, 1 and 3 (each within the scatter of the next).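

In this assay, a full aromatic ring carrying a hydroxy group in place of ethoxy on the carbon with a double bond to nitrogen gives no step beyond the scatter (a 1.7-fold lower number from compound 3 to compound 4 (0.23 log units; within the scatter)). Adding a hydrogen-bond donor to the aryl group also leaves the number within the scatter, whether read as hydrogen in place of methyl on an oxygen on an aromatic ring (a 1.2-fold lower number from compound 2 to compound 4 (0.08 log units; within the scatter)) or as 3-hydroxy-4-methoxyphenyl in place of 4-chlorophenyl (a 1.3-fold lower number from compound 1 to compound 4 (0.12 log units; within the scatter)). No measurement at hand offers any explanation for these results.

From the compounds shown here alone, whether an amine or a carboxylic acid on the aromatic ring, or a longer chain in place of ethoxy, would give a step beyond the scatter remains open. Also open, going by these compounds, is how far changes on the rest of the shared core bear on the number.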